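The source may hold more compounds than are shown below. What is called first, only, known or untested is meant among the compounds shown, and "the series" means these compounds.

In an ADME assay on Karpas-1106P cells (Homo sapiens) for cytotoxicity (a lower number here means that less compound is needed, a higher number that more compound is needed for the effect), compound 1 `Cc1ccc(S(=O)(=O)N[C@@H](CC(=O)NC(C)(C)C)C(=O)NCCNC(=O)c2cccc(O)c2)cc1` reads > 11100 nM as a limit. Compound 2 `Cc1ccc(S(=O)(=O)N[C@@H](CC(=O)NC(C)(C)C)C(=O)NCCNC(=O)c2c(O)cccc2F)cc1` reads > 11100 nM as a limit too. Both compounds stand at the limit of > 11100 nM in this assay, at which 2 of the 2 values shown sit, for now. Compound 3 `COc1cccc(C(=O)NCCNC(=O)[C@H](CC(=O)NC(C)(C)C)NS(=O)(=O)c2ccc(C)cc2)c1` differs from compound 2 by 3-methoxyphenyl in place of 2-fluoro-6-hydroxyphenyl on a carbonyl carbon with 3-methoxyphenyl in place of 2-fluoro-6-hydroxyphenyl on a carbonyl carbon. For the measured compounds named here, the one measured step is a step that the two limits leave unreadable from compound 1 to compound 2 and offers no size to carry over, so no step of readable size or direction is expected in this assay for this change. The expected outcome is a step that the limit leaves unreadable from compound 2 to compound 3 and nothing larger. For compound 3 the estimate is 15000 nM with an expected range of 7000 nM to 30000 nM and a reading at the limit is likely.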

Compound 3, half-maximal effective concentration: > 11100 nM
Compound 3: only a limit was reported (the forecaster's own chance of this, stated with the estimate: 85%); the middle value does not contradict the limit.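

No new step can be read, since compound 1, compound 2 and compound 3 all give only a limit: the limit of > 11100 nM in this assay, at which 3 of the 3 values shown sit.

The compounds shown leave open whether 3-hydroxyphenyl, 2-fluoro-6-hydroxyphenyl and 3-methoxyphenyl differ at all in this read-out.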